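Amide versus urea on the shared core: compound 4

The compounds below may be only part of what the source reports. "The series", "measured", "known", "first", "only" and "open" are said of these compounds alone.

The series keeps one core and varies the group on the carbonyl carbon. Compound 1 is `COc1cc(-c2nn(-c3cccc(NC(=O)c4cccc(C(F)(F)F)c4)c3)cc2-c2ccncc2)ccc1Cl`, compound 2 is `COc1cc(-c2nn(-c3cccc(NC(=O)Nc4cccc(C(F)(F)F)c4)c3)cc2-c2ccncc2)ccc1Cl`, compound 3 is `COc1cc(-c2nn(-c3cccc(NC(=O)c4ccc(Cl)c(C(F)(F)F)c4)c3)cc2-c2ccncc2)ccc1Cl`, and compound 4, not yet measured, is `COc1cc(-c2nn(-c3cccc(NC(=O)c4ccccc4)c3)cc2-c2ccncc2)ccc1Cl`.

In a functional assay on UACC-62 cells (Homo sapiens) for inhibition, read by sulforhodamine B assay, with a stated time of 48 h (a higher number here means a weaker inhibitor of growth, a lower number a stronger inhibitor of growth), compound 1 reaches only a limit, > 50000 nM. Compound 2 gives 1590 nM in this assay. Compound 3 likewise reaches only a limit in this assay, > 32500 nM. So compound 3 stands at a limit, and of the other two values one more is a limit (the limit of > 32500 nM in this assay, at which 1 of the 3 values shown sits, (the limit of > 50000 nM in this assay, at which 1 of the 3 values shown sits)).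

The readable steps are an at least 31-fold lower number from compound 1 to compound 2 (1.49 log units; beyond the scatter) and an at least 20-fold higher number from compound 2 to compound 3 (1.31 log units; beyond the scatter); between the two amides the step is a step that the two limits leave unreadable from compound 1 to compound 3.

The change to compound 4 is phenyl in place of 4-chloro-3-(trifluoromethyl)phenyl on a carbonyl carbon. Both measured amides sit at limits, and no readable step bears on substituents of the amide phenyl. Compound 4 is therefore expected to stay near the limit, with a step that the limit leaves unreadable from compound 3 to compound 4. The estimate for compound 4 is 40000 nM, expected between 8000 nM and 200000 nM.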

Compound 4, concentration for total growth inhibition: > 100000 nM
Compound 4 ended at the assay's limit (the forecaster's own chance of this, stated with the estimate: 70%); middle value at least 2.5-fold (0.39 log units) away from the limit.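

With plain phenyl on the carbonyl carbon, compound 4 also stands at a limit in this assay: the limit of > 100000 nM in this assay, at which 1 of the 4 values shown sits.

The amide therefore stays at a limit with neither the trifluoromethyl nor the chloro group on its phenyl, and of the compounds shown only the urea, compound 2, gives a number rather than a limit. For the compounds shown here, the one readable step is an at least 62-fold higher number from compound 2 to compound 4 (1.79 log units; beyond the scatter), whereas the steps among the three amides cannot be read, so no order of the amide phenyl substituents follows from them.

Open, going by these compounds, is whether a urea carrying phenyl or 4-chloro-3-(trifluoromethyl)phenyl would hold the number of compound 2. Also open, on these data alone, is whether a dimethylamino group or a carboxylic acid on the amide phenyl would bring an amide off the limit.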